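Adding a bromobenzoyl group to the amino compound

The source may hold more compounds than are shown below. What is called first, only, known or untested is meant among the compounds shown, and "the series" means these compounds.

Compound 3 `Cc1cc(N)c(=O)n(CC(=O)Nc2ccc(Br)cc2)n1` is the smallest of three compounds sharing one core; compound 1 `Cc1cc(Cc2cccc(F)c2)c(=O)n(CC(=O)Nc2ccc(Br)cc2)n1` and compound 2 `Cc1cc(Cc2cccc(Br)c2)c(=O)n(CC(=O)Nc2ccc(Br)cc2)n1` carry a benzyl group where compound 3 carries an amino group. In an assay on HL-60 cells for agonist activity at N-formyl peptide receptor 3 (Homo sapiens), read by calcium flux (a lower number here means that less compound is needed, a higher number that more compound is needed for the effect), compound 3 gives only a limit of the assay, > 50000 nM. Compound 1 likewise gives only a limit in this assay, > 50000 nM. Compound 2 also gives only a limit, > 50000 nM. All three values therefore sit at the same point, as summed up by the limit of > 50000 nM in this assay, at which 3 of the 3 values shown sit, and none of the steps between them can be read: neither a step that the two limits leave unreadable from compound 1 to compound 2, nor a step that the two limits leave unreadable from compound 1 to compound 3, nor a step that the two limits leave unreadable from compound 2 to compound 3.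

Compound 4 `Cc1cc(NC(=O)c2ccc(Br)cc2)c(=O)n(CC(=O)Nc2ccc(Br)cc2)n1` differs from compound 3 by (4-bromophenyl)carbonyl in place of hydrogen on a nitrogen on an aromatic ring, the nitrogen whose other neighbour is an aromatic carbon. The two steps that touch this nitrogen, from the benzyl compounds to compound 3, are unreadable, so they give no measured size to carry over; what remains is that every compound here sits at the limit. The step of an at least 1.2-fold lower number from compound 3 to compound 4 (0.09 log units; that floor lies within the scatter) is accordingly expected to stay small, most likely with the new compound again at or near the limit. For compound 4 the estimate in this assay is 40000 nM, within 5000 nM to 50000 nM.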

Compound 4, half-maximal effective concentration: > 50000 nM
Compound 4 gave a limit, no number; the forecaster's own chance of this, stated with the estimate: 70%; at least 1.2-fold (0.09 log units) between middle value and limit.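

In this assay compound 4 gives > 50000 nM, again a limit and not a number. Going by these compounds alone, compound 3 also stands at a limit, so no step from it to compound 4 can be read: the limit of > 50000 nM in this assay, at which 4 of the 4 values shown sit. The compounds shown leave open whether any change to the shared core would give a measurable number in this assay.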